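From Methoxy to Methyl on Compound 1

This account rests on a few compounds, and the source may have more. Where it says the series, first, only, none or still open, it means among the compounds named here.

For the measured compounds named here, in a functional assay on MCF7 cells (Homo sapiens) for antiproliferative activity, with a stated time of 5 days (a lower number here means a stronger inhibitor, a higher number a weaker inhibitor), compound 1 `COc1ccc(-c2[nH]c3ccc(C)cc3c2C=O)cc1` gives 140 nM, the higher of the two numbers measured so far, and compound 2 `CCCCCc1ccc2[nH]c(-c3ccc(OC)cc3)c(C=O)c2c1` gives 20 nM. The step between them, a 7.0-fold lower number from compound 1 to compound 2 (0.85 log units; beyond the scatter), is the only one measured, and it comes from butyl in place of hydrogen on a saturated chain carbon. Compound 3 `Cc1ccc(-c2[nH]c3ccc(C)cc3c2C=O)cc1` keeps the core of compound 1 but changes elsewhere, with methyl in place of methoxy on an aromatic carbon. The measured step therefore shows that one change can move the number beyond the scatter, but it does not bear directly on this replacement. No measurement fixes the direction, so a modest move towards a weaker inhibitor is only assumed. The expected step is a 2.1-fold higher number from compound 1 to compound 3 (0.33 log units; beyond the scatter). For compound 3 the estimated value is 300 nM, within an expected range of 90 nM to 900 nM.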

Compound 3, half-maximal inhibitory concentration: 165 nM
The estimate for compound 3 lay 1.8-fold (0.26 log units) above the measured number; measured number inside the range.
By their numbers in this assay, from the lowest: compound 2; then compounds 1 and 3 (each within the scatter of the next).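

In this assay the replacement of methoxy by methyl on an aromatic carbon, para to a large group, gives a 1.2-fold higher number from compound 1 to compound 3 (0.07 log units; within the scatter) and so stays within the scatter, unlike the earlier step made at a different place on the molecule. At this position, then, a group with a hydrogen-bond acceptor and one without cannot be told apart on these numbers, and the oxygen of the methoxy is not required to keep the number of compound 1. No measured evidence accounts for this result.

On these data alone, whether an amine or a carboxylic acid at this position would also stay within the scatter remains open. So does whether the same replacement would read alike on compound 2, with its longer chain on the shared core.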